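Hydroxy to methoxy in a small series

A few compounds are considered here, and "the series" means these few. Any claim that something is new, unique, unknown or untested is made for them only; others in the source may bear on it.

Values so far in a functional assay on OVCAR-4 cells (Homo sapiens) for antiproliferative activity, read by sulforhodamine B assay, with a stated time of 48 h; on this read-out higher numbers stand for weaker inhibition of growth and lower numbers for stronger inhibition of growth
compound 1 `O=C(NCCCNc1cc(-c2cn(-c3ccccc3)nc2-c2cccc(O)c2)ccn1)Nc1ccc(F)cc1` 8210 nM
compound 2 `O=C(NCCCNc1cc(-c2cn(-c3ccccc3)nc2-c2cccc(O)c2)ccn1)Nc1cccc(C(F)(F)F)c1` 7750 nM

Compound 1 has a single measured neighbour and holds no distinct rank in this set. Among the compounds with values here, the one measured step (a 1.1-fold lower number from compound 1 to compound 2 (0.03 log units; within the scatter)) puts 3-(trifluoromethyl)phenyl in place of 4-fluorophenyl on an amide-type nitrogen.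

Compound 3 `COc1cccc(-c2nn(-c3ccccc3)cc2-c2ccnc(NCCCNC(=O)Nc3ccc(F)cc3)c2)c1` departs from compound 1 elsewhere (methyl in place of hydrogen on an oxygen on an aromatic ring), with methyl in place of hydrogen on an oxygen on an aromatic ring, that is, 3-hydroxyphenyl to 3-methoxyphenyl. Within the data shown here, no measured pair carries this change, so the one step available bears on it only indirectly. That step shows that one exchange on the shared core stayed within the scatter, and it gives no direction for a change at the oxygen. With compound 1 at 8210 nM as the only anchor, no step beyond the scatter is expected in this assay, and the uncertainty is wide. The estimated step is (a 1.1-fold higher number from compound 1 to compound 3 (0.04 log units; within the scatter)). Compound 3 is expected at 9000 nM (estimated range 3500 nM to 25000 nM).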

Compound 3, concentration for total growth inhibition: > 37000 nM
Compound 3: a limit, no number (the forecaster's own chance of this, stated with the estimate: 10%); at least 4.1-fold (0.61 log units) between middle value and limit.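

In this assay, the reading for compound 3 is a limit of the assay and not a number: the limit of > 37000 nM in this assay, at which 1 of the 3 values shown sits. Methyl in place of hydrogen on the oxygen on the aromatic ring, that is, 3-hydroxyphenyl to 3-methoxyphenyl, gives an at least 4.5-fold higher number from compound 1 to compound 3 (0.65 log units; beyond the scatter), which marks weaker inhibition of growth and is the first step in this set beyond the scatter. Within the data shown here, the only earlier step, a 1.1-fold lower number from compound 1 to compound 2 (0.03 log units; within the scatter), concerned the group on the amide-type nitrogen, so this pair is the first sign that the read-out responds to what sits on this oxygen, though the sign rests on this one pair alone.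

From the compounds shown here alone, what an amine or a carboxylic acid would give in place of the hydroxy remains open, as does a longer chain than methyl on the oxygen, so the pair does not separate the effect of losing the hydroxy hydrogen from that of adding the methyl. Also open, going by these compounds, are the full size of the step, given the limit for compound 3, and whether the same change would carry over to compound 2 with its 3-(trifluoromethyl)phenyl group.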